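The source may hold more compounds than are shown below. What is called first, only, known or untested is meant among the compounds shown, and "the series" means these compounds.

Measured compounds:
- Compound 1 `CCn1c(-c2cnc(C)nc2)nc2c(N[C@H]3CCN(C(=O)[C@H]4C[C@@H](OC)C4)C3)ncnc21`: in an ADME assay on LLC-PK1 cells (Sus scrofa) for permeability (on this read-out higher numbers stand for higher permeability and lower numbers for lower permeability), compound 1 gives 10 10^-6 cm/s.
- Compound 2 `CCC(=O)N1CC[C@H](Oc2ncnc3c2nc(-c2cnc(C)nc2)n3CC)C1`: in this assay compound 2 gives 21 10^-6 cm/s.
- Compound 3 `CCC(=O)N1CC[C@H](Nc2ncnc3c2nc(-c2cnc(C)nc2)n3CC)C1`: in this assay compound 3 gives 21 10^-6 cm/s.

Compound 2 and compound 3 share most of their build but differ in their cores; the difference between the two cores is not broken down here. Their values in this assay are level at the digits shown, and that gap lies within the usual scatter, so nothing can be said of an order between them.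

Within the core of compound 3, one change has been measured: 3-methoxycyclobutyl in place of ethyl on a carbonyl carbon. It gave a 2.1-fold lower number from compound 3 to compound 1 (0.32 log units; beyond the scatter), a modest step that lies beyond the scatter.

Compound 4 `CCn1c(-c2cnc(C)nc2)nc2c(O[C@H]3CCN(C(=O)[C@H]4C[C@@H](OC)C4)C3)ncnc21` is the unmeasured partner. It differs from compound 2 by 3-methoxycyclobutyl in place of ethyl on a carbonyl carbon. The surroundings of the place are the same as in the change from compound 3 to compound 1, so this is the same change made within the core of compound 2.

Because compound 3 to compound 1 gave a 2.1-fold lower number from compound 3 to compound 1 (0.32 log units; beyond the scatter), a step of similar size is expected, a 2.1-fold lower number from compound 2 to compound 4 (0.32 log units; beyond the scatter). Compound 4 is therefore estimated at 10 10^-6 cm/s, with a likely range from 6 10^-6 cm/s to 17 10^-6 cm/s.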

Compound 4, apparent permeability: 18 10^-6 cm/s
The estimate for compound 4 lay 1.8-fold (0.26 log units) below the measured number; the whole stated range lies below it.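

In this assay, putting 3-methoxycyclobutyl in place of ethyl on the carbonyl carbon of compound 2 gave a 1.2-fold lower number from compound 2 to compound 4 (0.07 log units; within the scatter). Set beside the earlier step, the two readings do not part by more than the scatter allows: the same change on two cores in this assay, a 2.1-fold lower number (0.32 log units; beyond the scatter) from compound 3 to compound 1 and a 1.2-fold lower number (0.07 log units; within the scatter) from compound 2 to compound 4, 1.8-fold (0.26 log units) apart, within the scatter of two such steps. This gives no ground for saying that the change behaves differently on the two cores, but it does not establish that it carries over unchanged, as one step lies beyond the scatter, the other lies within it, and only two cores are shown.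

The compounds shown leave open how other groups on the carbonyl carbon would read, such as a plain cyclobutyl without the methoxy, a longer chain or an amine. Also open, from the compounds shown here alone, are whether the change holds on further cores and whether the other stereoisomers of the 3-methoxycyclobutyl group give similar numbers.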